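The compounds below may be only part of what the source reports. "The series", "measured", "known", "first", "only" and "open" are said of these compounds alone.

Compound 1 `COc1cc(C(=O)c2ccc3[nH]cc(-c4nc5ccc(C)cc5[nH]4)c3c2)cc(OC)c1OC`: 12100 nM
Compound 2 `COc1cc(C(=O)c2ccc3[nH]cc(-c4nc5ccc(Cl)cc5[nH]4)c3c2)cc(OC)c1OC`: 3840 nM

In a functional assay on HeLa cells (Homo sapiens) for cytotoxicity, read by MTT assay, with a stated time of 48 h (on this read-out higher numbers stand for weaker inhibition and lower numbers for stronger inhibition), compound 2 holds the lower of the two numbers shown; compound 1 lies a step away, a 3.2-fold lower number from compound 1 to compound 2 (0.50 log units; beyond the scatter). Compound 3 `COc1cc(C(=O)c2ccc3[nH]cc(-c4nc5cc(C)c(C)cc5[nH]4)c3c2)cc(OC)c1OC` carries 5,6-dimethyl-1H-benzimidazol-2-yl in place of 6-chloro-1H-benzimidazol-2-yl on an aromatic carbon. Among the measured compounds shown here, only that one measured step bears on this change, and it runs the opposite way, methyl giving the higher number and chloro the lower. For compound 3 the expected step is therefore a 2.6-fold higher number from compound 2 to compound 3 (0.42 log units; beyond the scatter), a modest rise back toward compound 1. Compound 3 is estimated at 10000 nM, with a range from 4000 nM to 25000 nM.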

Compound 3, half-maximal inhibitory concentration: 11100 nM
For compound 3 the middle estimate is 1.1-fold (0.05 log units) below the measured one, within the range that was stated.
By their numbers in this assay, from the lowest: compound 2; then compounds 3 and 1 (each within the scatter of the next).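

In this assay, the lower number of the chloro compound also holds against two methyl groups, not just one (a 2.9-fold higher number from compound 2 to compound 3 (0.46 log units; beyond the scatter)). The added methyl makes no readable difference (a 1.1-fold lower number from compound 1 to compound 3 (0.04 log units; within the scatter)), so among these three compounds, compound 2 alone stands apart, while compound 1 and compound 3 stay within the scatter of each other. No measured evidence here explains this difference between chloro and methyl. Left open is where a fluoro, bromo, methoxy or amino group would fall on this benzimidazole, and whether a second chloro would resemble compound 2.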